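Shortening the chain: cytotoxicity in a small pyrimidinol series

This account rests on a few compounds, and the source may have more. Where it says the series, first, only, none or still open, it means among the compounds named here.

Measured compounds:
compound 1 `CC(c1ccccc1)c1cc(O)nc(SC2CCCC2)n1` 159000 nM
compound 2 `CCC(c1ccccc1)c1cc(O)nc(SC2CCCC2)n1` 50000 nM
compound 3 `CCC(c1cc(O)nc(SC(C)C)n1)c1c(F)cccc1F` 130000 nM

Of the compounds shown here, three have been tested in a functional assay on MT4 cells (Homo sapiens) for cytotoxicity; a lower number here means that less compound is tolerated, a higher number that more compound is tolerated. Compound 2 gives 50000 nM, and compound 1 gives 159000 nM. The change between them, (hydrogen in place of methyl on a saturated chain carbon, two bonds along the chain from two aromatic carbons), produced a 3.2-fold higher number from compound 2 to compound 1 (0.50 log units; beyond the scatter). Compound 3 gives 130000 nM in this assay; the difference between the core of compound 3 and the core of compound 2 is not broken down here.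

Compound 4 `CC(C)Sc1nc(O)cc(C(C)c2c(F)cccc2F)n1` is not yet measured. It differs from compound 3 by hydrogen in place of methyl on a saturated chain carbon, two bonds along the chain from two aromatic carbons, the same change, at the same place, that led from compound 2 to compound 1. Resting on that single earlier step, compound 4 is expected to show a step of a 2.3-fold higher number from compound 3 to compound 4 (0.36 log units; beyond the scatter) from compound 3 in this assay, of roughly the size of a 3.2-fold higher number from compound 2 to compound 1 (0.50 log units; beyond the scatter), with wide uncertainty since only one such pair is known. Compound 4 is therefore estimated at 300000 nM, between 130000 nM and 700000 nM.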

Compound 4, half-maximal cytotoxic concentration: 167000 nM
For compound 4 the middle estimate is 1.8-fold (0.25 log units) above the measured one; low and high end bracket the measured number.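

In this assay, the exchange of methyl for hydrogen on the saturated chain carbon gives a 1.3-fold higher number from compound 3 to compound 4 (0.11 log units; within the scatter), a step that cannot be told apart from repeated measurement on this core. Set beside the earlier step, the result gives no sign that the change behaves differently on the two cores: the same change on two cores in this assay, a 3.2-fold higher number (0.50 log units; beyond the scatter) from compound 2 to compound 1 and a 1.3-fold higher number (0.11 log units; within the scatter) from compound 3 to compound 4, 2.5-fold (0.39 log units) apart, within the scatter of two such steps This shows that the earlier step is compatible with the new one, but it does not show that the change carries over at a fixed size, since only two pairs are available and only the earlier step lies beyond the scatter.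

The compounds shown leave open how a longer chain such as propyl, or an amine, would read in this assay if placed on that saturated chain carbon instead of the methyl. They also leave open whether the same exchange would give a step beyond the scatter on any further core.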